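The source may hold more compounds than are shown below. What is called first, only, known or untested is meant among the compounds shown, and "the series" means these compounds.

Measured in a functional assay on the whole organism (Abdomen) with Mus musculus as the target; a higher number here means that more compound is needed for the effect, a lower number that less compound is needed:
- compound 1 `CCc1nc(Cc2c[nH]cn2)c(C)s1`: > 30 mg/kg (a limit)
- compound 2 `Cc1nc(Cc2c[nH]cn2)sc1C`: 1.7 mg/kg
- compound 3 `CCc1nc(Cc2c[nH]cn2)sc1C`: > 30 mg/kg (a limit)

Compound 3 has only a limit and no number: > 30 mg/kg. That is the limit of > 30 mg/kg in this assay, at which 2 of the 3 values shown sit.

Compound 4 `CCc1csc(Cc2c[nH]cn2)n1` differs from compound 3 by one change: hydrogen in place of methyl on an aromatic carbon. In short, this is hydrogen in place of methyl on an aromatic carbon.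

Among the measured compounds shown here, only one measured step bears on this: an at least 17-fold higher number from compound 2 to compound 3 (1.24 log units; beyond the scatter). That step was methyl in place of hydrogen on a saturated chain carbon bound to an aromatic carbon, so it lies at a different place and offers only a loose guide. Still, it shows that a single added methyl can matter greatly on this core. Taking a methyl away is therefore expected to lower the number in this assay, though by an uncertain amount, and a second limit remains possible. The expected change is an at least 2.0-fold lower number from compound 3 to compound 4 (0.30 log units; that floor lies within the scatter). For compound 4 the estimate is 15 mg/kg, with an expected range from 2.5 mg/kg to 60 mg/kg.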

Compound 4, dose for half-maximal effect: > 30 mg/kg
Compound 4: a limit, no number (the forecaster's own chance of this, stated with the estimate: 45%); at least 2.0-fold (0.30 log units) between middle value and limit.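

Compound 4, like compound 3, gives only a limit and no number, so the step between these two compounds cannot be read. Both sit at the same limit: the limit of > 30 mg/kg in this assay, at which 3 of the 4 values shown sit.

Going by these compounds, whether hydrogen in place of methyl on an aromatic carbon changes the dose needed remains open.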